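The compounds below may be only part of what the source reports. "The series", "measured", "known", "first", "only" and "open" are said of these compounds alone.

Working notes on the series. Compound 1 `CCCCCCC#Cc1ccc(S(=O)(=O)Nc2cccc(-c3csc(NC(C)=O)n3)c2)cc1` gives 12.8% in a functional assay on A-375 cells (Homo sapiens) for antiproliferative activity, read by trypan blue exclusion, with a stated time of 48 h, tested at 5 uM; a higher number here means a weaker effect of the compound at the concentration tested, a lower number a stronger effect; this is the highest of the two numbers in hand, and the nearest is compound 2 `CCCCC#Cc1ccc(S(=O)(=O)Nc2cccc(-c3csc(NC(C)=O)n3)c2)cc1` with 9.3%, the step of a number 3.5 percentage points lower from compound 1 to compound 2 (within the scatter) lying within the scatter. Compound 3 `CCCCCCC#Cc1ccc(S(=O)(=O)Nc2cccc(-c3csc(Nc4ccccc4)n3)c2)cc1` differs from compound 1 by phenyl in place of acetyl on a nitrogen on an aromatic ring. For the measured compounds named here, the one measured step concerns the alkyl chain, not this nitrogen, so nothing measured bears on the change, and no step beyond the scatter is expected in either direction in this assay. For compound 3 the expected value is 15%, in the range 4% to 38%, a step of a number 2.2 percentage points higher from compound 1 to compound 3 (within the scatter).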

Compound 3, a percentage reported as activity, at one concentration (the size of the read-out at that concentration, not a potency): 59.2%
Beside the measured number, compound 3's estimate is 44.2 percentage points below it, outside the stated range (above it).
By their numbers in this assay, from the lowest: compounds 2 and 1 (each within the scatter of the next); then compound 3.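

In this assay, phenyl in place of acetyl on a nitrogen on an aromatic ring gives a number 46.4 percentage points higher from compound 1 to compound 3 (beyond the scatter), a weaker effect at the concentration tested. This nitrogen substituent therefore moves the read-out beyond the scatter, which the alkyl chain step did not. Nothing at hand accounts for the change from acetamido to anilino.

Still open, from the compounds shown here alone, is how a free amine, a benzoyl or a benzyl on this nitrogen would read. Also open, going by these compounds, is whether the same change on the shorter chain of compound 2 gives a step of similar size.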